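The compounds below may be only part of what the source reports. "The series", "measured", "known", "first", "only" and "open" are said of these compounds alone.

In a functional assay on U-87MG ATCC cells for antiproliferative activity against U-87 MG (Homo sapiens), read by spectrophotometry, with a stated time of 2 days (on this read-out higher numbers stand for weaker inhibition of growth and lower numbers for stronger inhibition of growth), compound 1 `Cc1ccc(Nc2ncc(C(F)(F)F)c(N3Cc4cccc(N(C)S(C)(=O)=O)c4C3)n2)cc1C` gives > 30000 nM, which is a limit of the assay and not a number. That places compound 1 at the limit of > 30000 nM in this assay, at which 1 of the 2 values shown sits. The other measured compound, compound 2 `COc1cc(N2CCN(C(C)=O)CC2)ccc1Nc1ncc(C(F)(F)F)c(N2Cc3cccc(N(C)S(C)(=O)=O)c3C2)n1`, shares the core of compound 1 but carries a different aryl group on the same nitrogen, and compound 2 gives a true number, 4700 nM.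

For the measured compounds named here, the next compound, compound 3 `Cc1ccc(Nc2ncc(C(F)(F)F)c(N3Cc4cccc(N(C)S(C)(=O)=O)c4C3)n2)c(Cl)c1`, keeps the core of compound 1 and changes only that aryl group. It has 2-chloro-4-methylphenyl in place of 3,4-dimethylphenyl on a nitrogen on an aromatic ring. Going by the values given here, the heavy-atom count stays the same, and no measured pair shows what this exchange does in this assay.

The expectation therefore rests on compound 1 and its limit of > 30000 nM, so no step beyond the scatter is foreseen, and no direction can be claimed. The expected change is an at least 1.2-fold lower number from compound 1 to compound 3 (0.07 log units; that floor lies within the scatter). For compound 3, the estimated value is 25000 nM, with an expected range from 9000 nM to 60000 nM.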

Compound 3, concentration for 50% growth inhibition: > 30000 nM
Compound 3: a limit, no number (the forecaster's own chance of this, stated with the estimate: 60%); middle value at least 1.2-fold (0.07 log units) away from the limit.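

In this assay compound 3 gives > 30000 nM as a limit of the assay and not a number. Compound 1 also stands at a limit, so no step can be read between compound 1 and compound 3: the limit of > 30000 nM in this assay, at which 2 of the 3 values shown sit. The compounds shown leave open whether exchanging 3,4-dimethylphenyl for 2-chloro-4-methylphenyl changes growth inhibition at all.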